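Methyl in place of fluoro on two related cores

This account rests on a few compounds, and the source may have more. Where it says the series, first, only, none or still open, it means among the compounds named here.

Compound 1 `Fc1ccc(OC[C@@H]2C[C@@H]3C[C@@H]3N2)cn1` and compound 2 `Cc1ccc(OC[C@@H]2C[C@@H]3C[C@@H]3N2)cn1` share one core. In an assay on CHO-K1 cells for displacement of a labelled ligand from Neuronal acetylcholine receptor; alpha4/beta2 (Homo sapiens), read by scintillation counting (a higher number here means a weaker inhibitor, a lower number a stronger inhibitor), compound 1 gives 1.2 nM and compound 2 gives 1.38 nM. The exchange methyl in place of fluoro on an aromatic carbon produced a 1.2-fold higher number from compound 1 to compound 2 (0.06 log units; within the scatter). Compound 3 `Fc1ncccc1OC[C@@H]1C[C@H]2C[C@H]2N1` has the same atoms joined differently; the difference between the two cores is not broken down here. In this assay compound 3 gives 17.4 nM, a higher number than either compound 1 or compound 2. Compound 4 `Cc1ncccc1OC[C@@H]1C[C@H]2C[C@H]2N1` is not yet measured; it differs from compound 3 by methyl in place of fluoro on an aromatic carbon, the same kind of change as between compound 1 and compound 2, but here the place is ortho to a group of 8 heavy atoms rather than para to it. Because a 1.2-fold higher number from compound 1 to compound 2 (0.06 log units; within the scatter) stayed within the scatter, the step of a 1.2-fold higher number from compound 3 to compound 4 (0.08 log units; within the scatter) is expected to be small as well. Compound 4 is therefore estimated at 21 nM, with a range from 9 nM to 50 nM.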

Compound 4, inhibition constant: > 10000 nM
Compound 4 was reported as a limit (the forecaster's own chance of this, stated with the estimate: 2%); middle value at least 470-fold (2.67 log units) away from the limit.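

In this assay compound 4 stands at > 10000 nM, a limit of the assay and not a number: the limit of > 10000 nM in this assay, at which 1 of the 4 values shown sits.

Methyl in place of fluoro on an aromatic carbon gives an at least 570-fold higher number from compound 3 to compound 4 (2.75 log units; beyond the scatter), so the small step seen on the core of compound 1 does not carry over to the core of compound 3: the same change on two cores in this assay, a 1.2-fold higher number (0.06 log units; within the scatter) from compound 1 to compound 2 and an at least 570-fold higher number (2.75 log units; beyond the scatter) from compound 3 to compound 4, at least 490-fold (2.69 log units) apart, beyond the scatter of two such steps

This does not show whether the core or the place accounts for the gap, since in compound 4 the methyl sits next to the ring nitrogen and ortho to a group of 8 heavy atoms, and the two pairs differ in both respects.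

Open, from the compounds shown here alone, is how methyl and fluoro compare at one and the same place on both cores. Also open, going by these compounds, is how a chloro, a methoxy or an amine would behave at the place occupied in compound 4.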